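Replacing a Hydroxyl Chain by a Dimethylamino Chain

A few compounds are considered here, and "the series" means these few. Any claim that something is new, unique, unknown or untested is made for them only; others in the source may bear on it.

Measured compounds:
compound 1, `CC(C)c1n[nH]c2c(NCc3ccc(-c4ccccn4)cc3)nc(SCCO)nc12`, 48 nM
compound 2, `CC(O)CSc1nc(NCc2ccc(-c3ccccn3)cc2)c2[nH]nc(C(C)C)c2n1`, 62 nM

Both compounds were tested in a functional assay on HT cells (Homo sapiens) for antiproliferative activity, read by fluorescence, with a stated time of 72 h; a lower number here means a stronger inhibitor of growth, a higher number a weaker inhibitor of growth. Compound 2 gives the higher of the two numbers, but its nearest neighbour is compound 1, and the step of a 1.3-fold higher number from compound 1 to compound 2 (0.11 log units; within the scatter) lies within the scatter, so the two cannot be told apart.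

Compound 3, `CC(C)c1n[nH]c2c(NCc3ccc(-c4ccccn4)cc3)nc(SCCCN(C)C)nc12`, has not yet been measured. It differs from compound 2 in one place: 2-(dimethylamino)ethyl in place of 1-hydroxyethyl on a saturated chain carbon bound to a sulfur.

Among the measured compounds shown here, the only measured step, from compound 1 to compound 2, altered the same sulfur-bound chain and changed nothing beyond the scatter. For the measured compounds named here, no measured step exchanges the hydroxyl for a dimethylamino group, so there is no direct precedent for that exchange. Going by the values given here, since the one change made on this chain left the number in place, the expected step of a 1.2-fold lower number from compound 2 to compound 3 (0.09 log units; within the scatter) is estimated to be small, with no clear direction. Compound 3 is therefore expected to give about 50 nM, within a range of 15 nM to 160 nM.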

Compound 3, concentration for 50% growth inhibition: 105 nM
Estimate against measurement, compound 3: 2.1-fold (0.32 log units) below; the measured number falls inside the stated range.
By their numbers in this assay, from the lowest: compounds 1, 2 and 3 (each within the scatter of the next, the first and the last beyond it).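

In this assay, among the compounds shown here, the step of a 2.2-fold higher number from compound 1 to compound 3 (0.34 log units; beyond the scatter) is the first on this sulfur-bound chain to pass beyond the scatter, and it is a modest one: the hydroxyl end of the chain in compound 1 can give way to a dimethylamino end in compound 3 with only a small loss of growth inhibition. The step of a 1.7-fold higher number from compound 2 to compound 3 (0.23 log units; within the scatter) stays within the scatter, so compound 3 cannot be told apart from compound 2, and the exchange reads as a change only against compound 1. Nothing available here speaks to the reason for the step.

In going to the 3-(dimethylamino)propyl chain, the chain length and the end group change together, so the compounds shown cannot say how much of the step belongs to each; a 2-(dimethylamino)ethyl chain attached to the sulfur, or a 3-hydroxypropyl chain, would separate the two. On these data alone, it also remains open how the chain behaves with other end groups, such as a primary amine, a morpholine ring or a carboxylic acid.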